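The compounds below may be only part of what the source reports. "The series", "measured", "known", "first", "only" and "open" are said of these compounds alone.

In an ADME assay on HCT-116 cells (Homo sapiens) for cytotoxicity, read by CellTiter-Glo, with a stated time of 72 h (a lower number here means a stronger inhibitor, a higher number a weaker inhibitor), compound 1 `COc1ccc(-c2cccc(S(=O)(=O)N3CCC(N4CCC(C)CC4)CC3)c2)cc1` gives > 5000 nM, which is a limit of the assay rather than a number. Compound 2 `CC1CCN(C2CCN(S(=O)(=O)c3cccc(-c4ccc(Cl)cc4)c3)CC2)CC1` gives > 5000 nM, again only a limit. Compound 3 `CC1CCN(C2CCN(S(=O)(=O)c3ccccc3-c3ccc(Cl)cc3)CC2)CC1` likewise gives > 5000 nM, a limit. All three measured values therefore sit at the limit of > 5000 nM in this assay, at which 3 of the 3 values shown sit, and no ordering among them can be drawn.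

Compound 1 differs from compound 2 by methoxy in place of chloro on an aromatic carbon, and the step that the two limits leave unreadable from compound 2 to compound 1 stays unreadable since both of its ends are limits. Compound 3 and compound 2 are built from the same atoms joined differently; the difference between their two cores is not broken down here.

Compound 4 `COc1ccc(-c2ccccc2S(=O)(=O)N2CCC(N3CCC(C)CC3)CC2)cc1` has not yet been measured in this assay. It differs from compound 3 by methoxy in place of chloro on an aromatic carbon, the same change that leads from compound 2 to compound 1, here made on the core of compound 3. Since that earlier change ran between two limits, it carries no size that could be transferred.

Compound 4 is expected to give 8000 nM in this assay, with a range estimated from 4000 nM to 30000 nM, and most probably it will again be reported only as a limit. That expectation rests on compound 3 giving > 5000 nM, a limit, together with the absence of any readable step for this change. The expected step is a step that the limit leaves unreadable from compound 3 to compound 4.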

Compound 4, half-maximal inhibitory concentration: > 5000 nM
Compound 4: only a limit was reported; the forecaster's own chance of this, stated with the estimate: 85%; the middle value is on the limit's open side.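

In this assay compound 4 gives > 5000 nM, which is a limit. Compound 3 also stands at a limit, so no size can be read for the change from compound 3 to compound 4. The compounds shown leave open whether the 4-chlorophenyl and 4-methoxyphenyl compounds, or the two cores, differ at all in this read-out, because every value rests at the same limit: the limit of > 5000 nM in this assay, at which 4 of the 4 values shown sit.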